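A few compounds are considered here, and "the series" means these few. Any claim that something is new, unique, unknown or untested is made for them only; others in the source may bear on it.

Working notes on the series. Compound 1 `CC(C)N(Cc1cccc(OCCCCCC(=O)O)c1)C(=O)c1ccc(-c2cccc(-c3ccccc3)c2)cc1` is the reference point in an ADME assay on HepG2 cells (Homo sapiens) for cytotoxicity, read by CellTiter-Glo and resazurin assay, with a stated time of 72 h (on this read-out higher numbers stand for an effect only at larger amounts of compound and lower numbers for an effect already at smaller amounts), and for compound 1 the assay returns only a limit, > 26000 nM. Compound 2 `COc1cc(OC)cc(-c2ccc(C(=O)N(Cc3cccc(OCCCCCC(=O)O)c3)C(C)C)cc2)c1` likewise returns only a limit, > 26000 nM. Compound 3 `CC(C)N(Cc1cccc(OCCCCCC(=O)O)c1)C(=O)c1ccc(-c2cccc(OC(F)(F)F)c2)cc1` also stops at a limit, > 26000 nM. All three values therefore sit at the limit of > 26000 nM in this assay, at which 3 of the 3 values shown sit, so compound 1 cannot be placed above or below its two neighbours; the steps a step that the two limits leave unreadable from compound 1 to compound 2, a step that the two limits leave unreadable from compound 1 to compound 3 and a step that the two limits leave unreadable from compound 2 to compound 3 are each left unreadable by the two limits.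

The next compound, compound 4 `CC(C)N(Cc1cccc(OCCCCCC(=O)O)c1)C(=O)c1ccc(-c2cccc(Br)c2)cc1`, differs from compound 1 by bromo in place of phenyl on an aromatic carbon. Among the compounds with values here, none of the three measured steps gives a readable size, so the only guidance is that every measured variation at this position of the shared core has stayed at the limit. The step that the limit leaves unreadable from compound 1 to compound 4 is therefore expected to be small or none beyond the scatter, with the value again most likely at a limit. For compound 4 the estimate in this assay is 40000 nM, within 20000 nM to 100000 nM.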

Compound 4, half-maximal effective concentration: > 26000 nM
Compound 4 was reported as a limit (the forecaster's own chance of this, stated with the estimate: 85%); the middle value does not contradict the limit.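

In this assay compound 4 gives > 26000 nM as a limit only. Within the data shown here, no step among compound 1, compound 2, compound 3 and compound 4 can be read, since all four stand at a limit: the limit of > 26000 nM in this assay, at which 4 of the 4 values shown sit. The compounds shown leave open whether any change at this position moves the half-maximal effective concentration.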